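Swapping the amide substituent: an expected cytotoxicity for compound 3

This account rests on a few compounds, and the source may have more. Where it says the series, first, only, none or still open, it means among the compounds named here.

Measured so far:
compound 1 `O=C(NCCO)c1cccc2[nH]c(-c3ccncc3)nc12`: 498 uM
compound 2 `O=C(Nc1ccccc1F)c1cccc2[nH]c(-c3ccncc3)nc12`: 111 uM

Both compounds share one core and differ only in the group on the amide-type nitrogen. In an ADME assay on Vero cells (Chlorocebus sabaeus) for cytotoxicity (on this read-out lower numbers stand for higher toxicity in this test and higher numbers for lower toxicity in this test), compound 1 gives 498 uM and compound 2 gives 111 uM. Compound 2 therefore stands at the lower of the two numbers, the step being a 4.5-fold lower number from compound 1 to compound 2 (0.65 log units; beyond the scatter).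

Compound 3 `Cc1csc(NC(=O)c2cccc3[nH]c(-c4ccncc4)nc23)n1` carries the change (4-methyl-1,3-thiazol-2-yl in place of 2-fluorophenyl on an amide-type nitrogen). Going by the values given here, the single measured step exchanged a short chain for a ring, whereas this step exchanges one ring for another of similar size, so no measured step speaks directly to it. With nothing pointing either way, the number for compound 3 is expected to stay within the scatter of compound 2, that is a 1.1-fold higher number from compound 2 to compound 3 (0.03 log units; within the scatter). The estimate for compound 3 in this assay is 120 uM, with a range from 50 uM to 300 uM.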

Compound 3, half-maximal toxic concentration: 111 uM
Compound 3: middle estimate off by 1.1-fold (0.03 log units), on the high side; the range from low to high includes it.
By their numbers in this assay, from the lowest: compounds 2 and 3 (each within the scatter of the next); then compound 1.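

In this assay the exchange of 2-fluorophenyl for 4-methyl-1,3-thiazol-2-yl on the amide-type nitrogen gives no change at the digits printed from compound 2 to compound 3 (within the scatter), so this position reads the same with a six-membered ring of carbon only and a five-membered aromatic ring with 2 hetero atoms, although the entering group counts 2 hydrogen-bond acceptors and the leaving group none. Against the 2-hydroxyethyl chain, the 4-methyl-1,3-thiazol-2-yl group gives a 4.5-fold lower number from compound 1 to compound 3 (0.65 log units; beyond the scatter), so the gap to compound 1 is not tied to the 2-fluorophenyl ring alone. No available measurement bears on why the two rings read alike.

Still open, from the compounds shown here alone, is how a longer chain, such as 4-hydroxybutyl, or a benzyl group would read at this position. The effect of a plain phenyl ring, or of one carrying an amine or a carboxylic acid, is also unknown.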